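Iodo to methoxy on the shared core

The source may hold more compounds than are shown below. What is called first, only, known or untested is meant among the compounds shown, and "the series" means these compounds.

In a functional assay on HOP-62 cells (Homo sapiens) for inhibition (a higher number here means a weaker inhibitor of growth, a lower number a stronger inhibitor of growth), compound 1 `NC(=O)c1cc(Cl)ccc1NC(=O)COc1ccccc1` gives 5880 nM and compound 2 `NC(=O)c1cc(I)ccc1NC(=O)COc1ccccc1` gives 824 nM. Among the measured compounds shown here, compound 2 therefore holds the lower of the two numbers so far. The next compound is compound 3 `COc1ccc(NC(=O)COc2ccccc2)c(C(N)=O)c1`, with methoxy in place of iodo on an aromatic carbon, meta to a carbamoyl group and para to a large group (methoxy in place of iodo on an aromatic carbon).

For the measured compounds named here, one measured step bears on this change: a 7.1-fold lower number from compound 1 to compound 2 (0.85 log units; beyond the scatter), a modest step beyond the scatter, with iodo in place of chloro at the same place. Going by the values given here, it shows that the number moves when this group is exchanged, but no methoxy compound has been measured, so the direction rests on a single pair. The lower number belongs to the iodo compound in the step of a 7.1-fold lower number from compound 1 to compound 2 (0.85 log units; beyond the scatter), so losing iodo is expected to raise the number by a similar size, back towards the level of compound 1. The expected change is a 4.2-fold higher number from compound 2 to compound 3 (0.63 log units; beyond the scatter). For compound 3 the estimated value is 3500 nM, with an expected range of 1100 nM to 12000 nM.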

Compound 3, concentration for 50% growth inhibition: 1010 nM
Beside the measured number, compound 3's estimate is 3.5-fold (0.54 log units) above it; the whole stated range lies above it.
By their numbers in this assay, from the lowest: compounds 2 and 3 (each within the scatter of the next); then compound 1.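

In this assay the exchange of iodo for methoxy gives a 1.2-fold higher number from compound 2 to compound 3 (0.09 log units; within the scatter) and so leaves compound 2 and compound 3 at one level on this read-out, even though the entering group differs in what is counted: methoxy brings 2 heavy atoms and 1 hydrogen-bond acceptor, iodo 1 heavy atom and 0 hydrogen-bond acceptors. Among the compounds shown here, the other new step is a 5.8-fold lower number from compound 1 to compound 3 (0.77 log units; beyond the scatter) and stands beyond the scatter, as the earlier step from chloro to iodo does, so among the three groups seen at this place chloro is the one set apart, and iodo is no longer the only group that reaches the lower level. No measurement of any property of these compounds accompanies the numbers, so the data offer no account of this pattern.

As far as these compounds go, it remains open whether the level shared by compound 2 and compound 3 extends to other groups at this place, such as an amine, a carboxylic acid or a longer chain. From the compounds shown here alone, it is also open whether fluoro or a plain hydrogen here would group with chloro or with the other two.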